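The source may hold more compounds than are shown below. What is called first, only, known or untested is meant among the compounds shown, and "the series" means these compounds.

Compound 3 `FC(F)(F)c1ccc(COc2ccc(Nc3ncnc4cc5c(cc34)OCCOCCOCCO5)cc2)cc1` was tested in a functional assay on SH-SY5Y cells (Homo sapiens) for antiproliferative activity, read by MTT assay, with a stated time of 72 h; on this read-out higher numbers stand for weaker inhibition and lower numbers for stronger inhibition. In this assay compound 3 gives > 100000 nM, which is a limit of the measurement rather than a number; it sits at the limit of > 100000 nM in this assay, at which 1 of the 3 values shown sits. Two further compounds were measured alongside. Compound 1 `c1ccc(COc2cccc(Nc3ncnc4cc5c(cc34)OCCOCCOCCO5)c2)cc1` gives 22800 nM in this assay, and compound 2 `FC(F)(F)c1ccc(COc2ccc(Nc3ncnc4cc5c(cc34)OCCOCCOCCOCCO5)cc2)cc1` gives 2140 nM. Compound 4 `c1ccc(COc2ccc(Nc3ncnc4cc5c(cc34)OCCOCCOCCO5)cc2)cc1` has not yet been measured; it differs from compound 3 in one place, (hydrogen in place of trifluoromethyl on an aromatic carbon). Among the compounds with values here, no step between two measured compounds is available to guide the expectation, so the size and direction of this change are uncertain. The step from compound 3 to compound 4 is expected to be an at least 2.0-fold lower number from compound 3 to compound 4 (0.30 log units; that floor lies within the scatter), toward stronger inhibition. Compound 4 is estimated at 50000 nM, with a range from 10000 nM to 300000 nM.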

Compound 4, half-maximal inhibitory concentration: 23900 nM
Compound 4: middle estimate off by 2.1-fold (0.32 log units), on the high side; low and high end bracket the measured number.
By their numbers in this assay, from the lowest: compound 2; then compounds 1 and 4 (each within the scatter of the next). At a limit, above all of these: compound 3.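

Replacing trifluoromethyl with hydrogen on this ring gives an at least 4.1-fold lower number from compound 3 to compound 4 (0.62 log units; beyond the scatter) in this assay, so at this position, on this core, the benzyloxy compound is the one that gives a measurable inhibition value. Compound 3 stands at a limit of the measurement and not at a number, so this step has only a floor and its full size stays unknown: the limit of > 100000 nM in this assay, at which 1 of the 4 values shown sits.

Still open, going by these compounds, is how a chlorine atom, a methoxy group or an amine at this place would compare with hydrogen and trifluoromethyl. Also open, on these data alone, is whether the same change gives a similar step on the core of compound 2.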